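This account rests on a few compounds, and the source may have more. Where it says the series, first, only, none or still open, it means among the compounds named here.

In a physicochemical assay for solubility, in phosphate buffer, measured as thermodynamic solubility, at pH 7.4 (on this read-out higher numbers stand for higher solubility and lower numbers for lower solubility), compound 3 `CS(=O)(=O)NC(=O)CCc1cn(-c2ccccc2Br)nc1-c1ccc(Cl)cc1` reads 165000 nM and compound 1 `CS(=O)(=O)NC(=O)CCc1cn(-c2ccc(Br)cc2)nc1-c1ccc(Cl)cc1` reads 170000 nM on the same scale, a pair within the scatter (a 1.0-fold lower number from compound 1 to compound 3 (0.01 log units; within the scatter)). Compound 2 `CS(=O)(=O)NC(=O)CCc1cn(-c2cccc(Br)c2)nc1-c1ccc(Cl)cc1` gives only a limit (< 5000 nM). The large step (an at least 33-fold higher number from compound 2 to compound 3 (1.51 log units; beyond the scatter)) keeps compound 3 far from that limit. Compound 4 `CS(=O)(=O)NC(=O)CCc1cn(-c2ccc(Cl)cc2)nc1-c1ccc(Cl)cc1` has 4-chlorophenyl in place of 2-bromophenyl on an aromatic nitrogen. For the measured compounds named here, no measured pair swaps bromine for chlorine. Compound 1, with 4-bromophenyl, is the closest guide (170000 nM), so no step beyond the scatter is expected in this assay here, although the large step (an at least 34-fold lower number from compound 1 to compound 2 (1.53 log units; beyond the scatter)) warns that sharp drops occur among these compounds. The expected step is small (a 1.1-fold lower number from compound 3 to compound 4 (0.04 log units; within the scatter)). Compound 4 is estimated at 150000 nM with an expected range from 40000 nM to 400000 nM in this read-out.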

Compound 4, solubility: 100000 nM
Estimate against measurement, compound 4: 1.5-fold (0.18 log units) above; low and high end bracket the measured number.
By their numbers in this assay, from the lowest: compounds 4, 3 and 1 (each within the scatter of the next). At a limit, below all of these: compound 2.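

In this assay, chloro in place of bromo on an aromatic carbon stays within the scatter (a 1.7-fold lower number from compound 1 to compound 4 (0.23 log units; within the scatter)), and 4-chlorophenyl matches 2-bromophenyl just as closely (a 1.7-fold lower number from compound 3 to compound 4 (0.22 log units; within the scatter)). The 3-bromophenyl compound now stands apart from a chlorinated partner too (an at least 20-fold higher number from compound 2 to compound 4 (1.30 log units; beyond the scatter)). Compound 2 still gives only a limit (< 5000 nM).

As far as these compounds go, whether 3-chlorophenyl would show the same sharp drop as 3-bromophenyl stays open. So does how an amine or a carboxylic acid on this phenyl ring would read.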